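This account rests on a few compounds, and the source may have more. Where it says the series, first, only, none or still open, it means among the compounds named here.

Measured in an assay on PEO1 cells for inhibition of Retinaldehyde dehydrogenase 3 (Homo sapiens), read by flow cytometry, with a stated time of 30 min, tested at 1 uM; a higher number here means more inhibition at the concentration tested (going by the name of the read-out), a lower number less inhibition:
compound 1 `CC(Sc1nc2nn(C3(C)COC3)cc2c(=O)n1-c1ccccc1)c1ccccc1` gives 90%
compound 2 `CC(Sc1nc2c(cnn2C)c(=O)n1-c1ccccc1)c1ccccc1` gives 47%
compound 3 `CC(Sc1nc2nn(C3COC3)cc2c(=O)n1-c1ccccc1)c1ccccn1` gives 99%

Compound 2 stands lowest of the three in this assay; compound 1 lies well above it, beyond the scatter, and compound 3 lies higher still, also beyond the scatter. For the measured compounds named here, neither of those pairs differs from compound 2 in one place only, so no single step has been measured.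

Compound 4 `CC(Sc1nc2c(cnn2C)c(=O)n1-c1ccccc1)c1cncnc1` has not yet been measured. Compared with compound 2 it carries the change (pyrimidin-5-yl in place of phenyl on a saturated chain carbon bound to a saturated chain carbon and a sulfur). Going by the values given here, no step of this kind is known among the measured compounds, so the expected change is small: the step of a number 5 percentage points higher from compound 2 to compound 4 (within the scatter) is estimated to lie within the scatter, perhaps slightly upward. Compound 4 is therefore expected to give about 52%, in a range from 25% to 78%.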

Compound 4, a percentage reported as inhibition, at one concentration (the size of the read-out at that concentration, not a potency): 39%
Compound 4: the middle estimate sits 13 percentage points above what was measured; the measured number falls inside the stated range.
By their numbers in this assay, from the lowest: compounds 4 and 2 (each within the scatter of the next); then compounds 1 and 3 (each within the scatter of the next).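

In this assay, for the compounds shown here, the change from 1-phenylethyl to 1-(pyrimidin-5-yl)ethyl gives the first single-place step at this position: a number 8 percentage points lower from compound 2 to compound 4 (within the scatter). On this core, then, pyrimidin-5-yl in place of phenyl brings in 2 hydrogen-bond acceptors without moving the read-out beyond the scatter. No evidence is available that would explain this result. As far as these compounds go, whether the same change behaves alike on the cores of compound 1 and compound 3 remains open. So does what an amine or a carboxylic acid would give in place of phenyl on this saturated chain carbon.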